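Furanylcarbonyl to tosyl on the amine nitrogen of compound 2

A few compounds are considered here, and "the series" means these few. Any claim that something is new, unique, unknown or untested is made for them only; others in the source may bear on it.

Three compounds of the series have numbers in a functional assay on A-431 cells (Homo sapiens) for cytotoxicity, read by MTT assay, with a stated time of 48 h; on this read-out higher numbers stand for weaker inhibition and lower numbers for stronger inhibition. Compound 1 `CCCCCCCCNC(=O)[C@@H](NC(=O)c1ccco1)[C@@H](C)O` gives 64500 nM, compound 2 `CCCCCCCCCCCCCCNC(=O)[C@@H](NC(=O)c1ccco1)[C@@H](C)O` gives 190000 nM, and compound 3 `CCCCCCCCCCCCCCNC(=O)[C@@H](NC(=O)c1nccc2ccccc12)[C@@H](C)O` gives 23000 nM. Compound 2 stands highest of the three: compound 1 is nearest, through a 2.9-fold higher number from compound 1 to compound 2 (0.47 log units; beyond the scatter), and compound 3 is furthest, through an 8.3-fold lower number from compound 2 to compound 3 (0.92 log units; beyond the scatter).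

Compound 4 `CCCCCCCCCCCCCCNC(=O)[C@@H](NS(=O)(=O)c1ccc(C)cc1)[C@@H](C)O` differs from compound 2 by (4-methylphenyl)sulfonyl in place of (furan-2-yl)carbonyl on an amine nitrogen. Within the data shown here, only the step between compound 2 and compound 3 touches the same nitrogen; there the exchange of one aromatic carbonyl group for another gave an 8.3-fold lower number from compound 2 to compound 3 (0.92 log units; beyond the scatter). The exchange in compound 4 brings in a sulfonyl rather than a carbonyl, so that step is a weak guide. The expectation is a modest lowering, not more, with a wide range. For compound 4 the estimated step is a 2.4-fold lower number from compound 2 to compound 4 (0.38 log units; beyond the scatter). Compound 4 is therefore expected to give about 80000 nM in this assay, within 20000 nM to 300000 nM.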

Compound 4, half-maximal inhibitory concentration: 12000 nM
For compound 4 the middle estimate is 6.7-fold (0.82 log units) above the measured one, and the stated range ends above it.
By their numbers in this assay, from the lowest: compounds 4 and 3 (each within the scatter of the next); then compound 1; then compound 2.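

The amine nitrogen of compound 2 accepts a sulfonyl link as well as a carbonyl link: in this assay, (4-methylphenyl)sulfonyl in place of (furan-2-yl)carbonyl gives a 16-fold lower number from compound 2 to compound 4 (1.20 log units; beyond the scatter), a large step. Compound 3 at 23000 nM and compound 4 at 12000 nM lie within the scatter of each other, so two quite different groups on this nitrogen end at one level, and both stand clear of the furan-2-yl carbonyl of compound 2. Nothing available accounts for the size of this step.

On these data alone, the step changes both the link and the aromatic ring, so it stays open which of them carries it; a 4-methylbenzoyl or a methanesulfonyl group on this nitrogen would separate the two. Also open, as far as these compounds go, is whether the (4-methylphenyl)sulfonyl group acts alike with the shorter chain of compound 1.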